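The source may report more compounds than this note shows. Statements on the series, on what has been measured and on what is new or still open speak of the compounds shown alone.

Working notes on the series in a functional assay on HCC827 cells (Homo sapiens) for inhibition, read by fluorescence, with a stated time of 72 h; a higher number here means a weaker inhibitor of growth, a lower number a stronger inhibitor of growth. Compound 3 `CCCCn1cnc2c(Nc3ccc(Cl)cc3)nc(N[C@H]3CC[C@H](N)CC3)nc21` gives 10800 nM. Compound 1 `CCCCCCn1cnc2c(Nc3cccc(Cl)c3)nc(N[C@H]3CC[C@H](N)CC3)nc21` gives 10200 nM and compound 2 `CCCCn1cnc2c(Nc3cc(OC)cc(OC)c3)nc(N[C@H]3CC[C@H](N)CC3)nc21` gives 20100 nM. The value of compound 3 lies within the scatter of both, so the three numbers show no order that can be relied on.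

Compound 4 `CCCCn1cnc2c(Nc3cccc(Cl)c3)nc(N[C@H]3CC[C@H](N)CC3)nc21` differs from compound 3 as follows: 3-chlorophenyl in place of 4-chlorophenyl on a nitrogen on an aromatic ring. This puts 3-chlorophenyl in place of 4-chlorophenyl on a nitrogen on an aromatic ring, with the same atoms joined differently.

Going by the values given here, only one measured step changes the group on this nitrogen: a 1.9-fold lower number from compound 2 to compound 3 (0.27 log units; within the scatter). Even that exchange of 3,5-dimethoxyphenyl for 4-chlorophenyl stays within the scatter. Among the compounds with values here, no measured step isolates the exchange of 4-chlorophenyl for 3-chlorophenyl. Compound 1, which also carries 3-chlorophenyl, gives 10200 nM, within the scatter of compound 3. These results give no ground for expecting a real shift in either direction in this assay.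

The estimated change is a 1.0-fold lower number from compound 3 to compound 4 (0.01 log units; within the scatter), with nothing expected beyond the scatter. For compound 4 the expected value is 10500 nM, with an estimated range of 5500 nM to 20000 nM.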

Compound 4, concentration for 50% growth inhibition: 7200 nM
Compound 4: the middle estimate sits 1.5-fold (0.16 log units) above what was measured, within the range that was stated.
By their numbers in this assay, from the lowest: compounds 4, 1, 3 and 2 (each within the scatter of the next, the first and the last beyond it).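

In this assay, 3-chlorophenyl in place of 4-chlorophenyl on a nitrogen on an aromatic ring gives a 1.5-fold lower number from compound 3 to compound 4 (0.18 log units; within the scatter), so this exchange, now measured on its own, shows no reliable preference between the two chlorophenyl groups. Going by these compounds alone, the group on this nitrogen can still shift the number: 3-chlorophenyl in place of 3,5-dimethoxyphenyl gives a 2.8-fold lower number from compound 2 to compound 4 (0.45 log units; beyond the scatter), the only step so far beyond the scatter, while 4-chlorophenyl in the same exchange gave a 1.9-fold lower number from compound 2 to compound 3 (0.27 log units; within the scatter). With 3-chlorophenyl held fixed, hydrogen in place of ethyl on the saturated chain gives a 1.4-fold lower number from compound 1 to compound 4 (0.15 log units; within the scatter), so that change in chain length has no reliable effect on the number.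

The data shown offer no measurement that accounts for any of these steps. From the compounds shown here alone, it stays open whether the modest step belongs to the loss of the two methoxy groups or to the arrival of chlorine, and whether another group on this nitrogen, such as 3-aminophenyl or 3-carboxyphenyl, or a methyl in place of the chain on the aromatic nitrogen, would move the number well beyond the scatter.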